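The source may hold more compounds than are shown below. What is called first, only, known or untested is meant among the compounds shown, and "the series" means these compounds.

Among the measured compounds shown here, compound 2 `COC(=O)c1sc2ccccc2c1C#Cc1ccc(F)cc1` stands second highest of the three numbers so far in a functional assay on cells (CNS cell, Homo sapiens) for cytotoxicity, read by sulforhodamine B assay, with a stated time of 48 h (on this read-out lower numbers stand for stronger inhibition of growth and higher numbers for weaker inhibition of growth), where compound 2 gives 56200 nM. For the measured compounds named here, compound 1 `COC(=O)c1sc2ccccc2c1C#Cc1ccc(OC)cc1` gives 103000 nM in this assay, and the only one-place step measured so far is a 1.8-fold lower number from compound 1 to compound 2 (0.26 log units; within the scatter). Going by the values given here, compound 3 `COC(=O)c1sc2cc(OC)ccc2c1C#Cc1ccccc1` gives 42300 nM in this assay; it differs from compound 2 in more than one place, so no step is counted for that pair, and the two values only show that they lie close to each other.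

Compound 4 `COC(=O)c1sc2ccccc2c1C#Cc1ccccc1F` has not yet been measured. It differs from compound 2 in one place: 2-fluorophenyl in place of 4-fluorophenyl on a triple-bonded carbon. Among the compounds with values here, no measured step in this set rearranges the same atoms in this way, so the nearest guide is the step from compound 1 to compound 2, which exchanged the group on the same ring and stayed within the scatter. Nothing among the three measured compounds has yet moved the value beyond the scatter, and the change to compound 4 keeps every atom of compound 2. The step expected for compound 4, a 1.0-fold lower number from compound 2 to compound 4 (0.00 log units; within the scatter), is therefore none beyond the scatter. Compound 4 is estimated at 56000 nM, with a range from 25000 nM to 120000 nM.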

Compound 4, concentration for 50% growth inhibition: 30200 nM
For compound 4 the middle estimate is 1.9-fold (0.27 log units) above the measured one; low and high end bracket the measured number.
By their numbers in this assay, from the lowest: compounds 4, 3, 2 and 1 (each within the scatter of the next, the first and the last beyond it).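

In this assay, among the compounds shown here, 2-fluorophenyl in place of 4-fluorophenyl on a triple-bonded carbon gives a 1.9-fold lower number from compound 2 to compound 4 (0.27 log units; within the scatter), the first step that keeps every atom and alters only how they are joined. Read with a 1.8-fold lower number from compound 1 to compound 2 (0.26 log units; within the scatter), it shows that neither exchanging the group on this ring nor rearranging the fluoro-substituted ring has yet produced a one-place step beyond the scatter, so these compounds give no sign that the values at this place depend on either change. Nothing at hand explains these values or this lack of separation.

On these data alone, the three one-place comparisons available are too few and too small to define what this place will accept, and it remains open whether a more different group, such as an amine or a carboxylic acid on the same ring, would give a step beyond the scatter. For the compounds shown here, also open is whether a change elsewhere on the shared core, or replacing the methyl ester with an amide, would move the values further than any change at this place so far.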